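The source may report more compounds than this note shows. Statements on the series, on what has been measured and on what is new or still open speak of the compounds shown alone.

Compound 1 `CCc1ccc(/C=C/[C@@H]2CCCCN2)cc1`: 4.13 ug/mL
Compound 2 `CC(=O)c1ccc(/C=C/[C@@H]2CCCCN2)cc1`: 2.7 ug/mL
Compound 3 `C(=C/[C@@H]1CCCCN1)\c1ccccc1`: 9.15 ug/mL

These three compounds were tested in a functional assay on MCF7 cells (Homo sapiens) for inhibition, read by MTT assay, with a stated time of 24 h; on this read-out lower numbers stand for stronger inhibition and higher numbers for weaker inhibition. Compound 3 has the highest number of the three, making it the weakest inhibitor measured so far. The next compound, compound 4 `COc1ccc(/C=C/[C@@H]2CCCCN2)cc1`, differs from compound 3 by a single change: methoxy in place of hydrogen on an aromatic carbon.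

Going by the values given here, two measured steps bear most directly on this change, since each involves hydrogen and another group at the same aromatic carbon. Replacing ethyl with hydrogen gave a 2.2-fold higher number from compound 1 to compound 3 (0.35 log units; beyond the scatter), and replacing acetyl with hydrogen gave a 3.4-fold higher number from compound 2 to compound 3 (0.53 log units; beyond the scatter). Both steps are modest but beyond the scatter. Read in reverse, they show that each of these two groups goes with a lower number than hydrogen does. Ethyl and acetyl are not separated here, as the exchange between them gave a 1.5-fold lower number from compound 1 to compound 2 (0.18 log units; within the scatter), which is within the scatter.

Methoxy has not yet been measured on this core, and two groups are a narrow basis for a trend, so the expectation is a loose one. A modest gain in inhibition is expected, with an estimated step of a 2.0-fold lower number from compound 3 to compound 4 (0.31 log units; beyond the scatter). The estimate for compound 4 is 4.5 ug/mL, with an expected range from 2.3 ug/mL to 9 ug/mL.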

Compound 4, half-maximal inhibitory concentration: 3.57 ug/mL
Compound 4: middle estimate off by 1.3-fold (0.10 log units), on the high side; the measured number falls inside the stated range.
By their numbers in this assay, from the lowest: compounds 2, 4 and 1 (each within the scatter of the next); then compound 3.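

Methoxy in place of hydrogen gave a 2.6-fold lower number from compound 3 to compound 4 (0.41 log units; beyond the scatter) in this assay, making it the third group on this aromatic carbon to go with a lower number than hydrogen. Methoxy does not separate from the other two groups: the exchange for acetyl gave a 1.3-fold higher number from compound 2 to compound 4 (0.12 log units; within the scatter) and the exchange for ethyl gave a 1.2-fold lower number from compound 1 to compound 4 (0.06 log units; within the scatter), and both steps lie within the scatter. Across these four compounds, the clear difference is therefore between hydrogen and any of the three groups, with no compound going against it, and no order can be drawn among ethyl, acetyl and methoxy even though they differ in their atoms.

Nothing shown here explains why these three groups behave alike in this test. Going by these compounds, it remains open whether the same holds for quite different groups on this carbon, such as an amine, a carboxylic acid or a longer chain, and whether any of them would separate from ethyl, acetyl and methoxy rather than fall alongside them.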